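Shortening the para substituent: tert-butyl to methyl

A few compounds are considered here, and "the series" means these few. Any claim that something is new, unique, unknown or untested is made for them only; others in the source may bear on it.

Three ureas on a shared core have been measured in an assay on isolated protein for inhibition of acyl-CoA:cholesterol acyltransferase (Oryctolagus cuniculus); a lower number here means a stronger inhibitor, a higher number a weaker inhibitor. Compound 1 `CCCCCCc1ccc(NC(=O)Nc2c(C(C)C)cccc2C(C)C)cc1` gives 26 nM and compound 2 `CCCCc1ccc(NC(=O)Nc2c(C(C)C)cccc2C(C)C)cc1` gives 29 nM; the step of a 1.1-fold higher number from compound 1 to compound 2 (0.05 log units; within the scatter) lies within the scatter. Compound 3 `CC(C)c1cccc(C(C)C)c1NC(=O)Nc1ccc(C(C)(C)C)cc1` gives 168 nM and stands highest of the three, with the steps of a 6.5-fold higher number from compound 1 to compound 3 (0.81 log units; beyond the scatter) and a 5.8-fold higher number from compound 2 to compound 3 (0.76 log units; beyond the scatter) both beyond the scatter.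

Compound 4 `Cc1ccc(NC(=O)Nc2c(C(C)C)cccc2C(C)C)cc1` differs from compound 3 by methyl in place of tert-butyl on an aromatic carbon. Within the data shown here, no measured step removes or shortens a substituent to methyl; the nearest evidence is that the two straight chains of compound 1 and compound 2 sit close together, while the branched tert-butyl of compound 3 sits higher. Methyl shares the straight form but none of the length, so the bearing of these steps is uncertain, and the expected step of a 1.4-fold lower number from compound 3 to compound 4 (0.15 log units; within the scatter) is estimated as small, without a direction beyond the scatter. Compound 4 is therefore expected to give about 120 nM in this assay, with a range from 40 nM to 400 nM.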

Compound 4, half-maximal inhibitory concentration: 250 nM
For compound 4 the middle estimate is 2.1-fold (0.32 log units) below the measured one, and the stated range covers the measured number.
By their numbers in this assay, from the lowest: compounds 1 and 2 (each within the scatter of the next); then compounds 3 and 4 (each within the scatter of the next).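

In this assay, the step of a 1.5-fold higher number from compound 3 to compound 4 (0.17 log units; within the scatter) lies within the scatter, so methyl and tert-butyl on this aromatic carbon, para to a large group, are not separated. The steps of an 8.6-fold higher number from compound 2 to compound 4 (0.94 log units; beyond the scatter) and a 9.6-fold higher number from compound 1 to compound 4 (0.98 log units; beyond the scatter) are both beyond the scatter, which places the straight methyl apart from butyl and hexyl, just as the branched tert-butyl was already placed. Straight form alone therefore does not bring compound 4 to the values of compound 1 and compound 2, and among these four compounds only butyl and hexyl give the lower numbers.

On these data alone, how an ethyl or propyl chain, a chain longer than hexyl, or an amine at this position would read remains open. No measurement offered here accounts for these steps.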